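The source may report more compounds than this note shows. Statements on the series, on what has been measured and on what is new or still open speak of the compounds shown alone.

The measured compounds: compound 1 `CC1CCN(c2c(S(=O)(=O)c3cccc(F)c3)cnc3ccc(F)cc23)CC1`, which in an assay on isolated protein for displacement of a labelled ligand from metabotropic glutamate receptor 5 (Homo sapiens), with a stated time of 60 min, tested at 1 uM (a higher number here means more inhibition at the concentration tested (going by the name of the read-out), a lower number less inhibition), gives 76%; compound 2 `CC1CCN(c2c(S(=O)(=O)c3cccc(F)c3)cnc3ccc(Cl)cc23)CC1`, which in this assay gives 58%; and compound 3 `COc1ccc2ncc(S(=O)(=O)c3cccc(C#N)c3)c(N3CCC(C)CC3)c2c1`, which in this assay gives 90%.

Compound 1 stands second of the three. Compound 3 lies above it, beyond the scatter, and compound 2 lies below it, also beyond the scatter, since a number 18 percentage points lower from compound 1 to compound 2 (beyond the scatter).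

Compound 4 `Cc1ccc(S(=O)(=O)c2cnc3ccc(F)cc3c2N2CCC(C)CC2)cc1Cl` is not yet measured. It differs from compound 1 in one place: 3-chloro-4-methylphenyl in place of 3-fluorophenyl on a sulfonyl sulfur.

Going by the values given here, only one step is known, and it does not touch the same part of the molecule: the exchange of chloro for fluoro in the step from compound 1 to compound 2 gave a modest fall, beyond the scatter. That is the only hint that a larger halogen may cost something, and it comes from a different position, so it is a weak guide. Compound 3, with a nitrile in place of the fluorine on the phenyl attached to the sulfonyl sulfur, gives a higher number in this assay than compound 1, but it also carries a second change, so it cannot be read alone.

Taken together, a modest fall or no step beyond the scatter is expected, so for compound 4 an inhibition of 65% is estimated, with a range from 40% to 85%, meaning an expected step of a number 11 percentage points lower from compound 1 to compound 4 (beyond the scatter).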

Compound 4, a percentage reported as inhibition, at one concentration (the size of the read-out at that concentration, not a potency): 91%
Compound 4: middle estimate off by 26 percentage points, on the low side, outside the stated range (above it).
By their numbers in this assay, from the lowest: compound 2; then compound 1; then compounds 3 and 4 (each within the scatter of the next).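

Compound 4 shows that the ring on the sulfonyl sulfur can take more than a single fluorine without a loss: in this assay, placing 3-chloro-4-methylphenyl there in place of 3-fluorophenyl gives a number 15 percentage points higher from compound 1 to compound 4 (beyond the scatter). A chlorine in this part of the molecule therefore does not repeat the change seen elsewhere on the core, where chloro in place of fluoro gave a number 18 percentage points lower from compound 1 to compound 2 (beyond the scatter), so that earlier step cannot be carried over from one place to the other. Nothing available here explains the rise in inhibition.

The new group differs from the old one in two ways at once, so the compounds shown leave open how much of the step belongs to the chlorine and how much to the methyl, a question that 3-chlorophenyl and 4-methylphenyl on the same sulfonyl sulfur would help to separate. Also open, going by these compounds, is how this position would respond to a quite different substituent on the ring, such as an amine, a carboxylic acid or a longer chain.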